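Methoxymethyl Removal in a Series Tested for Antiproliferative Activity

A few compounds are considered here, and "the series" means these few. Any claim that something is new, unique, unknown or untested is made for them only; others in the source may bear on it.

Compound 3 `CCCC/C=C\CCCCCCCCCc1cc(=O)c2c(O)c(C)c(OCOC)c(C)c2o1` was examined in a functional assay on MCF7 cells (Homo sapiens) for antiproliferative activity, read by MTT assay (a lower number here means a stronger inhibitor, a higher number a weaker inhibitor), where compound 3 reaches only the limit > 67200 nM. Compound 1 `CCCC/C=C\CCCCCCCCCc1cc(=O)c2c(O)c(C)c(O)c(C)c2o1` differs from compound 3 by hydrogen in place of methoxymethyl on an oxygen on an aromatic ring. In this assay compound 1 likewise gives only the limit > 67200 nM. The step that the two limits leave unreadable from compound 3 to compound 1 is therefore one that the two limits leave unreadable. Compound 2 `CCCCC/C=C\C/C=C\CCCCCCCc1cc(=O)c2c(O)c(C)c(OCOC)cc2o1` rests on a different core; the difference between the cores of compound 2 and compound 3 is not broken down here. In this assay compound 2 also gives only the limit > 67200 nM. Among the measured compounds shown here, every value so far sits at the limit of > 67200 nM in this assay, at which 3 of the 3 values shown sit, so no measured step in this set can be sized.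

Compound 4 `CCCCC/C=C\C/C=C\CCCCCCCc1cc(=O)c2c(O)c(C)c(O)cc2o1` is derived from compound 2 by hydrogen in place of methoxymethyl on an oxygen on an aromatic ring, the same change, at the same kind of place, as from compound 3 to compound 1. Since that earlier change read a step that the two limits leave unreadable from compound 3 to compound 1, the step is expected to be a step that the limit leaves unreadable from compound 2 to compound 4. Compound 4 is accordingly estimated at about 100000 nM, most likely again reported only as a limit, within an expected range from 30000 nM to 300000 nM.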

Compound 4, half-maximal inhibitory concentration: > 84100 nM
Compound 4: only a limit was reported (the forecaster's own chance of this, stated with the estimate: 85%); the middle value is on the limit's open side.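

In this assay compound 4 gives only the limit > 84100 nM. As compound 2 also stands only at a limit, the step between compound 2 and compound 4 cannot be read. The compounds shown leave open what any of them would give as an actual number in this assay, and so whether hydrogen in place of methoxymethyl changes the read-out at all.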